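One stereocentre left undrawn in a cytotoxic compound

The source may report more compounds than this note shows. Statements on the series, on what has been measured and on what is new or still open speak of the compounds shown alone.

Measured in a functional assay on MCF7 cells (Homo sapiens) for cytotoxicity, read by WST assay, with a stated time of 72 h; on this read-out lower numbers stand for stronger inhibition and higher numbers for weaker inhibition:
- compound 1 `Cc1c(F)ccc2c1NC(=O)C2(c1ccc(O)cc1)C1CCCCCC1`: 20 nM
- compound 2 `COc1ccc2c(c1C)NC(=O)C2(c1ccc(O)cc1)c1ccc(F)cc1`: 6.3 nM
- compound 3 `COc1ccc2c(c1C)NC(=O)[C@]2(c1ccc(O)cc1)C1CCCCCC1`: 0.48 nM

Compound 3 has the lowest number of the three, and the gaps to the other two lie beyond the usual scatter of repeated measurements. Compound 2 comes closest and compound 1 lies furthest away.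

The next compound to be tested is compound 4 `COc1ccc2c(c1C)NC(=O)C2(c1ccc(O)cc1)C1CCCCCC1`. It has the same atoms and bonds as compound 3, and the only difference lies in how it is drawn: the two compounds have the same atoms and bonds; at least one stereo element is drawn with a configuration in one of them and without one in the other: 1 of 1 stereo elements differ; a stereocentre at a saturated ring carbon is drawn S in compound 3 and without a configuration in compound 4. A stereocentre drawn without a configuration leaves open which form or forms the sample holds. Going by the values given here, no measured pair here shows what such a difference does to the number, so the expectation rests on the structures alone. Compound 4 shares every atom and bond with compound 3 at 0.48 nM, so it should stay close to that value, perhaps slightly weaker. The expected step is a 1.9-fold higher number from compound 3 to compound 4 (0.27 log units; within the scatter), a small move toward weaker inhibition that is not expected to clear the scatter. For compound 4 the estimated value is 0.9 nM, with an expected range from 0.4 nM to 2.5 nM.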

Compound 4, half-maximal inhibitory concentration: 4.7 nM
Compound 4: the middle estimate sits 5.2-fold (0.72 log units) below what was measured; measured number outside the range, above it.
By their numbers in this assay, from the lowest: compound 3; then compounds 4 and 2 (each within the scatter of the next); then compound 1.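

In this assay, how this saturated ring carbon is drawn goes with a clear shift, a 9.8-fold higher number from compound 3 to compound 4 (0.99 log units; beyond the scatter), and only one thing separates the pair: the fact that one of compounds 3 and 4 is drawn with a defined configuration and the other without, at the place where they differ

Among compounds left undrawn at this carbon, cycloheptyl in place of 4-fluorophenyl gives a 1.3-fold lower number from compound 2 to compound 4 (0.13 log units; within the scatter), whereas methoxy in place of fluoro gives a 4.3-fold lower number from compound 1 to compound 4 (0.63 log units; beyond the scatter). Compounds 1 and 2 could not show it, but the low number of compound 3 at 0.48 nM goes with the centre drawn S, not with the atoms and bonds alone.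

Which form or forms the sample of compound 4 holds remains open, as does the number for a sample holding only the form drawn R. Also open is how the S form would respond to an ethoxy in place of the methoxy or a cyclopentyl in place of the cycloheptyl.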